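Urea series: from trifluoromethylbenzyl to dichlorobenzyl ether

This account rests on a few compounds, and the source may have more. Where it says the series, first, only, none or still open, it means among the compounds named here.

Measured in a functional assay on HT-29 cells (Homo sapiens) for inhibition, read by MTT assay, with a stated time of 48 h; on this read-out lower numbers stand for stronger inhibition and higher numbers for weaker inhibition:
compound 1, `Cc1ccc(NC(=S)NC(=O)c2ccc(OCc3ccccc3F)cc2)cc1-c1nc2ccccc2[nH]1`, gives 1870 nM
compound 2, `Cc1ccc(NC(=S)NC(=O)c2ccc(OCc3cccc(F)c3)cc2)cc1-c1nc2ccccc2[nH]1`, gives 55300 nM
compound 3, `Cc1ccc(NC(=O)NC(=O)c2ccc(OCc3ccc(C(F)(F)F)cc3)cc2)cc1-c1nc2ccccc2[nH]1`, gives 7830 nM

Among these three numbers compound 3 stands second highest in this assay: compound 1 sits at a lower number and compound 2 at a higher one, and both gaps lie beyond the scatter. Compound 4, `Cc1ccc(NC(=O)NC(=O)c2ccc(OCc3ccc(Cl)cc3Cl)cc2)cc1-c1nc2ccccc2[nH]1`, differs from compound 3 in a single place: 2,4-dichlorophenyl in place of 4-(trifluoromethyl)phenyl on a saturated chain carbon bound to an oxygen on an aromatic ring. Among the compounds with values here, only one measured step touches the aryl group on that same saturated chain carbon, namely a 30-fold higher number from compound 1 to compound 2 (1.47 log units; beyond the scatter), a large move. That step, however, shifts a single fluorine within the thiourea pair, while compounds 3 and 4 keep the urea of compound 3 and exchange one substituent pattern for another. Within the data shown here, no measured pair repeats this exchange, so its direction cannot be read from the data; the one step shows only that changes on this ring can move the number considerably. Compound 4 is therefore expected to give about 7000 nM in this assay, with a wide range from 1500 nM to 30000 nM. The step of a 1.1-fold lower number from compound 3 to compound 4 (0.05 log units; within the scatter) is estimated to be none beyond the scatter, with low confidence.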

Compound 4, half-maximal inhibitory concentration: 2620 nM
Compound 4: the middle estimate sits 2.7-fold (0.43 log units) above what was measured; the range from low to high includes it.
By their numbers in this assay, from the lowest: compounds 1 and 4 (each within the scatter of the next); then compound 3; then compound 2.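

In this assay, the urea pair adds a second measured step at the aryl group on a saturated chain carbon bound to an oxygen on an aromatic ring: a 3.0-fold lower number from compound 3 to compound 4 (0.48 log units; beyond the scatter), a modest gain in inhibition with 2,4-dichlorophenyl in place of 4-(trifluoromethyl)phenyl. Within the data shown here, until now the only step at this place was the fluorine shift within the thiourea pair, a 30-fold higher number from compound 1 to compound 2 (1.47 log units; beyond the scatter), so the new result shows that the aryl group also changes the number when the urea is kept, and it gives a direction for this particular exchange. Nothing available here explains why the dichlorinated group gives the lower number.

The exchange alters the substituents in more than one respect at once, so the compounds shown leave open whether the chlorines, the loss of trifluoromethyl or both account for the step, and whether the same exchange would have a similar effect with the thiourea of compound 1. They also leave open how a pyridyl ring or a cyclohexyl group would compare at this place.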